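Bromo in place of benzamido: expected growth inhibition

A few compounds are considered here, and "the series" means these few. Any claim that something is new, unique, unknown or untested is made for them only; others in the source may bear on it.

The series is read in a functional assay on PC-3 cells (Homo sapiens) for inhibition, read by sulforhodamine B assay; on this read-out higher numbers stand for weaker inhibition of growth and lower numbers for stronger inhibition of growth. In this assay compound 3 `O=C(CCC1=CCCN(Cc2ccc(NC(=O)c3ccccc3)cc2)C1=O)NO` gives > 10000 nM, which is a limit and not a number. Compound 1 `CC(=O)Nc1ccc(CN2CCC=C(CCC(=O)NO)C2=O)cc1` gives > 10000 nM, also a limit. Compound 3 thus sits at the limit of > 10000 nM in this assay, at which 2 of the 3 values shown sit. Going by the values given here, compound 2 `Cc1ccc(CN2CCC=C(CCC(=O)NO)C2=O)cc1` gives 8100 nM, the one true number so far.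

Compound 4 `O=C(CCC1=CCCN(Cc2ccc(Br)cc2)C1=O)NO` carries bromo in place of benzamido on an aromatic carbon.

Among the compounds with values here, two measured steps bear on this change. Benzamido in place of methyl gave an at least 1.2-fold higher number from compound 2 to compound 3 (0.09 log units; that floor lies within the scatter), and methyl in place of acetamido gave an at least 1.2-fold lower number from compound 1 to compound 2 (0.09 log units; that floor lies within the scatter). Both sizes are floors within the scatter, so neither fixes a true size. The nearest reference for compound 4 is compound 2 at 8100 nM. A modest move towards a lower number is expected, and a reading that returns only a limit remains possible. The expected step is an at least 1.4-fold lower number from compound 3 to compound 4 (0.15 log units; that floor lies within the scatter). Compound 4 is estimated at 7000 nM, with an expected range of 2500 nM to 20000 nM.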

Compound 4, concentration for 50% growth inhibition: 3150 nM
Compound 4: the middle estimate sits 2.2-fold (0.35 log units) above what was measured; the range from low to high includes it.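

In this assay, going by these compounds alone, bromo on this aromatic carbon gives the first step with a true number at both ends and a size beyond the scatter: a 2.6-fold lower number from compound 2 to compound 4 (0.41 log units; beyond the scatter), a change of a single substituent. Floors that stayed within the scatter now clear it, with an at least 3.1-fold lower number from compound 3 to compound 4 (0.50 log units; beyond the scatter) on replacing benzamido and an at least 3.1-fold lower number from compound 1 to compound 4 (0.50 log units; beyond the scatter) on replacing acetamido. Compound 1 and compound 3 each remain a limit and not a number: the limit of > 10000 nM in this assay, at which 2 of the 4 values shown sit.

Bromo is the only halogen shown on this carbon, so it remains open whether chloro, iodo, an amine or a carboxylic acid there would read like bromo or like methyl. From the compounds shown here alone, the true sizes of the steps from the two limit compounds, and the unreadable step between them, also remain open.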